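The source may hold more compounds than are shown below. What is called first, only, known or untested is meant among the compounds shown, and "the series" means these compounds.

Compound 1 `O=C1NC(NCc2ccccc2)=N/C1=C\c1c[nH]c2ncccc12` is the starting point. In a functional assay on A2780 cells (Homo sapiens) for antiproliferative activity, read by a luciferase reporter, with a stated time of 72 h (a higher number here means a weaker inhibitor, a lower number a stronger inhibitor), compound 1 gives 1200 nM. Compound 2 `O=C1NC(NCc2ccco2)=N/C1=C\c1c[nH]c2ncccc12` differs from it by a single change, (furan-2-yl in place of phenyl on a saturated chain carbon bound to an amine nitrogen), and in this assay compound 2 gives 4000 nM; the step is a 3.3-fold higher number from compound 1 to compound 2 (0.52 log units; beyond the scatter). Compound 3 `O=C1N=C(NCc2ccccc2)S/C1=C\c1c[nH]c2ncccc12` has a different core; how the two cores differ is not broken down here. In this assay compound 3 gives 320 nM, the lowest of the three measured numbers. Compound 4 `O=C1N=C(NCc2ccco2)S/C1=C\c1c[nH]c2ncccc12` is not yet measured; it differs from compound 3 by furan-2-yl in place of phenyl on a saturated chain carbon bound to an amine nitrogen, the same change at the same place as that from compound 1 to compound 2. The step from compound 3 to compound 4 is expected to be about a 3.1-fold higher number from compound 3 to compound 4 (0.49 log units; beyond the scatter), resting on the earlier step of a 3.3-fold higher number from compound 1 to compound 2 (0.52 log units; beyond the scatter). Compound 4 is therefore estimated at 1000 nM, with a likely range from 450 nM to 2500 nM.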

Compound 4, half-maximal inhibitory concentration: 1200 nM
Estimate against measurement, compound 4: 1.2-fold (0.08 log units) below, within the range that was stated.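

In this assay the swap of phenyl for furan-2-yl gives a 3.8-fold higher number from compound 3 to compound 4 (0.57 log units; beyond the scatter), so the number moves the same way as it did on the core of compound 1. The size of the step carried over from one core to the other: the same change on two cores in this assay, a 3.3-fold higher number (0.52 log units; beyond the scatter) from compound 1 to compound 2 and a 3.8-fold higher number (0.57 log units; beyond the scatter) from compound 3 to compound 4, 1.1-fold (0.05 log units) apart, within the scatter of two such steps. Going by these compounds alone, this rests on only two pairs in one assay, so it supports carrying this one change between these two cores, but it does not show that the step would hold on a third core or explain why it occurs.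

The compounds shown leave open how other groups on that chain carbon, such as a pyridine ring or a longer chain, would behave. They also leave open whether those groups would give matching steps on both cores.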